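The source may report more compounds than this note shows. Statements on the series, on what has been measured and on what is new or still open speak of the compounds shown alone.

Compound 2 `COc1ccccc1N1CCN(C(=O)C2(C)CCc3c(C)c(O)c(C)c(C)c3O2)CC1` gives 15000 nM in a functional assay (brain) for inhibition, with Rattus norvegicus as the target (a lower number here means a stronger inhibitor, a higher number a weaker inhibitor), the highest of the two numbers shown. Compound 1 `Cc1c(C)c2c(c(C)c1O)CCC(C)(C(=O)N1CCN(c3cc(N4CCCC4)nc(N4CCCC4)n3)CC1)O2` gives 500 nM in this assay, a markedly lower number, well beyond the scatter. Compound 3 `Cc1c(C)c2c(c(C)c1O)CCC(C)(C(=O)N1CCN(c3ncccn3)CC1)O2` has not yet been measured. It differs from compound 2 in one place: pyrimidin-2-yl in place of 2-methoxyphenyl on an amine nitrogen in a ring. For the measured compounds named here, no measured pair shows this exchange, so its size is unknown. A moderate fall in the number is expected, the estimated step of a 3.0-fold lower number from compound 2 to compound 3 (0.48 log units; beyond the scatter) lying beyond the scatter. Compound 3 is estimated at 5000 nM, within 1000 nM to 25000 nM.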

Compound 3, half-maximal inhibitory concentration: 23000 nM
Compound 3: the middle estimate sits 4.6-fold (0.66 log units) below what was measured; measured number inside the range.
By their numbers in this assay, from the lowest: compound 1; then compounds 2 and 3 (each within the scatter of the next).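

In this assay, placing pyrimidin-2-yl in place of 2-methoxyphenyl on the amine nitrogen in the ring gives a 1.5-fold higher number from compound 2 to compound 3 (0.19 log units; within the scatter) and so leaves the number within the scatter. At this position, a carbon-only aromatic ring and an aromatic ring with 2 hetero atoms therefore cannot be told apart, even though the methoxy group is lost. Nothing given here accounts for this result. Still open, on these data alone, is whether a benzyl group or a plain alkyl chain on this same nitrogen would move the number, and whether pyridin-2-yl would match these two groups.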